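The source may report more compounds than this note shows. Statements on the series, on what has been measured and on what is new or still open speak of the compounds shown alone.

In an ADME assay on Vero cells (Chlorocebus sabaeus) for inhibition, read by MTT assay, with a stated time of 72 h (a higher number here means a weaker inhibitor, a lower number a stronger inhibitor), compound 1 (`O=C(O)CCCCCCC(=O)Nc1ccc(C2=C(c3ccc(O)cc3)C3CC(S(=O)(=O)Oc4ccccc4C(F)(F)F)C2O3)cc1`) gives > 100000 nM as a limit of the assay and not as a number. Compound 2 (`O=S(=O)(Oc1ccccc1)[C@H]1C[C@H]2O[C@@H]1C(c1ccc(O)cc1)=C2c1ccc(O)cc1`) gives > 100000 nM as a limit too. Compound 3 (`O=C(CCCCCCC(=O)Nc1ccc(C2=C(c3ccc(O)cc3)C3CC(S(=O)(=O)Oc4ccccc4)C2O3)cc1)NO`) likewise gives > 100000 nM as a limit. Compound 1 therefore has no exact place on the scale and shares its position with both other compounds, all of them resting on the limit of > 100000 nM in this assay, at which 3 of the 3 values shown sit, with nothing to rank them.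

Compound 4 (`O=C(O)CCCCCCC(=O)Nc1ccc(C2=C(c3ccc(O)cc3)C3CC(S(=O)(=O)Oc4ccc5ccccc5c4)C2O3)cc1`) keeps the shared core of compound 1 and alters a single group, with naphthalen-2-yl in place of 2-(trifluoromethyl)phenyl on an oxygen whose other neighbour is the sulfonyl sulfur. The counted change is naphthalen-2-yl in place of 2-(trifluoromethyl)phenyl on an oxygen and the two groups have the same number of heavy atoms. Going by the values given here, no measured pair in this set isolates that exchange. The expectation rests on compound 1 with its limit of > 100000 nM as the starting point. The expected a number no higher from compound 1 to compound 4 (the limit leaves the size open) in this assay is no change beyond the scatter, in neither direction. For compound 4 the estimated value is 100000 nM with an expected range from 50000 nM to 200000 nM and the assay may well report only a limit again.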

Compound 4, half-maximal inhibitory concentration: > 100000 nM
Compound 4 was reported as a limit; the forecaster's own chance of this, stated with the estimate: 85%; the middle value lies on the limit itself.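

In this assay compound 4 gives > 100000 nM, again a limit and not a number. No step can be read from compound 1 to compound 4, because both rest on the same limit: the limit of > 100000 nM in this assay, at which 4 of the 4 values shown sit.

The compounds shown leave open whether naphthalen-2-yl in place of 2-(trifluoromethyl)phenyl on an oxygen changes the read-out in this assay at all.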